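A few compounds are considered here, and "the series" means these few. Any claim that something is new, unique, unknown or untested is made for them only; others in the source may bear on it.

Compound 1 `O=C(CCCCCCC(=O)c1ccccc1)NO` gives 500 nM in an assay on isolated protein for inhibition of histone deacetylase 8 (Homo sapiens); a lower number here means a stronger inhibitor, a higher number a weaker inhibitor.
Compound 2 `COc1ccc(C(=O)CCCCCCC(=O)NO)cc1` gives 450 nM in this assay.
Compound 3 `COc1ccc(CS(=O)(=O)Nc2ccc(/C=C\C(=O)NO)cc2)cc1` gives 60 nM in this assay.

Compound 2 differs from compound 1 by methoxy in place of hydrogen on an aromatic carbon, a change that produced a step of a 1.1-fold lower number from compound 1 to compound 2 (0.05 log units; within the scatter). Compound 3 is built on a different core; the difference between the two cores is not broken down here. Compound 4 `COc1ccc(CS(=O)(=O)Nc2ccc(/C=C\C(=O)NO)cc2)cc1OC` has not yet been measured in this assay; it differs from compound 3 by methoxy in place of hydrogen on an aromatic carbon. This is the same kind of change as that from compound 1 to compound 2, though the surroundings differ: in compound 2 the group sits para to a large group, while in compound 4 it sits ortho to a methoxy group and meta to a large group. Because the earlier step was a 1.1-fold lower number from compound 1 to compound 2 (0.05 log units; within the scatter), a similar step of a 1.1-fold lower number from compound 3 to compound 4 (0.04 log units; within the scatter) is expected here. Compound 4 is therefore estimated at 55 nM in this assay, most likely between 25 nM and 130 nM.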

Compound 4, half-maximal inhibitory concentration: 90 nM
The estimate for compound 4 lay 1.6-fold (0.21 log units) below the measured number; low and high end bracket the measured number.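

Methoxy in place of hydrogen on an aromatic carbon gave a 1.5-fold higher number from compound 3 to compound 4 (0.18 log units; within the scatter) in this assay, so on this core, as on the core of compound 1, the change produced no step beyond the scatter. As far as these numbers can tell, the change carried from one core to the other: the same change on two cores in this assay, a 1.1-fold lower number (0.05 log units; within the scatter) from compound 1 to compound 2 and a 1.5-fold higher number (0.18 log units; within the scatter) from compound 3 to compound 4, 1.7-fold (0.22 log units) apart, within the scatter of two such steps

This does not prove that the two steps are identical, and two steps are too few to set a rule for other cores or other ring positions. The compounds shown leave open whether a different group on this aromatic carbon, such as an amine, a carboxylic acid or a longer alkoxy chain, would give a step beyond the scatter on either core.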